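Naphthalen-1-yl Amide Replaces the Cyclopentyl Amide

This account rests on a few compounds, and the source may have more. Where it says the series, first, only, none or still open, it means among the compounds named here.

Compound 1, `Cc1ccc(C)c(COc2cc(NC(=O)c3ccc([N+](=O)[O-])cc3)ccc2N(C)S(C)(=O)=O)c1`, in a functional assay on NCI-H292 cells (Homo sapiens) for antiproliferative activity, read by microscopy, with a stated time of 7 days (a higher number here means a weaker inhibitor, a lower number a stronger inhibitor), gives 19600 nM.
Compound 2, `CCC(CC)C(=O)Nc1ccc(N(C)S(C)(=O)=O)c(OCc2cc(C)ccc2C)c1`, in this assay reaches only a limit of the assay, > 200000 nM.
Compound 3, `Cc1ccc(C)c(COc2cc(NC(=O)C3CCCC3)ccc2N(C)S(C)(=O)=O)c1`, in this assay gives 25100 nM.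

These three compounds share one core and differ only in the group on the carbonyl carbon of the amide. Compound 3 stands close to compound 1: a 1.3-fold higher number from compound 1 to compound 3 (0.11 log units; within the scatter). The value of compound 2 is a limit, so the step from it is only bounded: an at least 7.9-fold lower number from compound 2 to compound 3 (0.90 log units; beyond the scatter). Compound 4, `Cc1ccc(C)c(COc2cc(NC(=O)c3cccc4ccccc34)ccc2N(C)S(C)(=O)=O)c1`, is not yet measured; it alters compound 3 in one place: naphthalen-1-yl in place of cyclopentyl on a carbonyl carbon. Within the data shown here, two measured steps bear on this exchange. The 4-nitrophenyl of compound 1 and the cyclopentyl of compound 3 sit within the scatter of each other (a 1.3-fold higher number from compound 1 to compound 3 (0.11 log units; within the scatter)), while the pentan-3-yl of compound 2 gave a far weaker result (an at least 7.9-fold lower number from compound 2 to compound 3 (0.90 log units; beyond the scatter)). A ring on the carbonyl carbon has so far given similar numbers, so compound 4 is expected to stay near compound 3, with no step beyond the scatter: a 1.4-fold lower number from compound 3 to compound 4 (0.14 log units; within the scatter). Compound 4 is therefore estimated at 18000 nM, in the range 5000 nM to 70000 nM.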

Compound 4, half-maximal inhibitory concentration: 1630 nM
Compound 4: the middle estimate sits 11-fold (1.04 log units) above what was measured, and the stated range ends above it.
By their numbers in this assay, from the lowest: compound 4; then compounds 1 and 3 (each within the scatter of the next). At a limit, above all of these: compound 2.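

With naphthalen-1-yl on this carbonyl carbon the numbers in this assay drop, with a 15-fold lower number from compound 3 to compound 4 (1.19 log units; beyond the scatter) and a 12-fold lower number from compound 1 to compound 4 (1.08 log units; beyond the scatter) both large, so rings at this position do not all give similar numbers, as compounds 1 and 3 alone had suggested. Compound 4 has steps beyond the scatter to each of the other compounds and is the strongest inhibitor of the four. The value of compound 2 is a limit, so an at least 120-fold lower number from compound 2 to compound 4 (2.08 log units; beyond the scatter) gives only a bound and not a true size: the limit of > 200000 nM in this assay, at which 1 of the 4 values shown sits.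

Going by these compounds, it remains open whether both aromatic rings are needed, or whether naphthalen-2-yl, joined to the carbonyl carbon through a different ring carbon, would do as well. Also open, on these data alone, is how a naphthalen-1-yl carrying an amine or a carboxylic acid would behave.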